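The compounds below may be only part of what the source reports. "The series", "measured", "known", "first", "only" and "open" are said of these compounds alone.

In a functional assay on DU-145 cells (Homo sapiens) for inhibition, read by MTT assay, with a stated time of 48 h (on this read-out higher numbers stand for weaker inhibition and lower numbers for stronger inhibition), compound 1 (`COc1ccc(-c2nc3ccccn3c2Sc2ccccc2)cc1`) gives 76800 nM and compound 2 (`c1ccc(Sc2c(-c3cccc4ccccc34)nc3ccccn23)cc1`) gives 60600 nM as values within the usual scatter of each other. Compound 3 (`Clc1ccc(-c2nc3ccccn3c2Sc2ccccc2)cc1`) has chloro in place of methoxy on an aromatic carbon, para to a large group (chloro in place of methoxy on an aromatic carbon). Within the data shown here, no measured pair shows this change, so no step beyond the scatter is expected in this assay and no direction is favoured. The estimated step is small (a 1.4-fold lower number from compound 1 to compound 3 (0.14 log units; within the scatter)). The expected value for compound 3 is 55000 nM (estimated range 22000 nM to 110000 nM).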

Compound 3, half-maximal inhibitory concentration: 30700 nM
Beside the measured number, compound 3's estimate is 1.8-fold (0.25 log units) above it; the measured number falls inside the stated range.
By their numbers in this assay, from the lowest: compounds 3, 2 and 1 (each within the scatter of the next, the first and the last beyond it).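

In this assay, among these compounds, the aromatic carbon para to a large group proves sensitive to substitution: 4-methoxyphenyl to 4-chlorophenyl gives a 2.5-fold lower number from compound 1 to compound 3 (0.40 log units; beyond the scatter), the first single-place step, and it lies beyond the scatter. The change removes methoxy and introduces chloro together, so this single pair cannot separate the contribution of each group. No evidence on the cause of the step is at hand.

Open, as far as these compounds go, is how a fluoro, an amine or a carboxylic acid at this place would compare with chloro. Also open, from the compounds shown here alone, is whether the same change gives a similar step elsewhere on the core of compound 1.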